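Compound 1 to compound 4: losing one methoxy

The compounds below may be only part of what the source reports. "The series", "measured", "known", "first", "only" and "open" are said of these compounds alone.

Of the compounds shown here, three have been read in a functional assay on HeLa cells (Homo sapiens) for cytotoxicity, read by WST assay, with a stated time of 48 h; on this read-out lower numbers stand for stronger inhibition and higher numbers for weaker inhibition. Compound 1 `COc1cccc([C@@H]2OC[C@H]([C@@H](O)c3ccc(OC)c(OC)c3)C[C@H]2C/C=C/c2ccc(OC)c(OC)c2)c1` gives 30100 nM. Compound 2 `COc1ccc(/C=C/C[C@@H]2C[C@@H]([C@@H](O)c3ccc(OC)c(OC)c3)CO[C@H]2c2ccc(OC)c(OC)c2)cc1` gives 17100 nM, within the scatter of compound 1. Compound 3 `Oc1ccc(/C=C/C[C@H]2C[C@@H]([C@@H](O)c3ccccc3)CO[C@@H]2c2ccccc2)cc1` gives 14400 nM, a lower number than compound 1 and only just beyond the scatter.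

Compound 4 `COc1ccc(/C=C/C[C@@H]2C[C@@H]([C@@H](O)c3ccc(OC)c(OC)c3)CO[C@H]2c2ccccc2)cc1OC` is still unmeasured. It differs from compound 1 by 3-methoxyphenyl to phenyl, hydrogen in place of methoxy on an aromatic carbon. Among the compounds with values here, no measured pair isolates a single change, so no direct step is available as a guide. Compound 3 also carries a phenyl group, and its 14400 nM gives weak support for a slightly lower number, though it differs from compound 4 in other places too.

The estimated step of a 1.4-fold lower number from compound 1 to compound 4 (0.16 log units; within the scatter) is expected to point towards a lower number and stay within the scatter. For compound 4 the expected value is 21000 nM, with an estimated range of 10000 nM to 42000 nM.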

Compound 4, half-maximal inhibitory concentration: 16100 nM
For compound 4 the middle estimate is 1.3-fold (0.12 log units) above the measured one; the range from low to high includes it.
By their numbers in this assay, from the lowest: compounds 3, 4, 2 and 1 (each within the scatter of the next, the first and the last beyond it).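

In this assay, within the data shown here, compound 1 and compound 4 form the first pair that differs in one place only, and hydrogen in place of methoxy on an aromatic carbon gives a 1.9-fold lower number from compound 1 to compound 4 (0.27 log units; within the scatter). The methoxy meta to a large group can therefore go, as 3-methoxyphenyl to phenyl, without a change beyond the scatter, and both compounds remain in the same micromolar band as the rest of the series. Nothing available accounts for this tolerance or says what the methoxy contributes at this position.

The compounds shown leave open whether an amine or a carboxylic acid on this aromatic carbon would move the number beyond the scatter. From the compounds shown here alone, whether the methoxy groups on the other aromatic rings can be lost as readily also stays open.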